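The source may hold more compounds than are shown below. What is called first, only, known or untested is meant among the compounds shown, and "the series" means these compounds.

Three compounds have been tested in an ADME assay on HEL cells (Homo sapiens) for cytotoxicity; on this read-out higher numbers stand for lower toxicity in this test and lower numbers for higher toxicity in this test:

Compound 1 `C/C(=N\NC(=O)COc1cccc2ccccc12)c1ccc(C#N)cc1Br` gives 20 ug/mL.
Compound 2 `C/C(=N\NC(=O)COc1cccc2ccccc12)c1ccc([N+](=O)[O-])cc1` gives 100 ug/mL.
Compound 3 `C/C(=N\NC(=O)COc1cccc2ccccc12)c1ccccc1O` gives 20 ug/mL.

Compound 3 stands level with compound 1, the two together giving the lowest numbers of the three, while compound 2 stands apart: a 5.0-fold lower number from compound 2 to compound 3 (0.70 log units; beyond the scatter), and likewise a 5.0-fold higher number from compound 1 to compound 2 (0.70 log units; beyond the scatter). Within this small set only the compound carrying the 4-nitrophenyl reaches a higher number.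

Compound 4 `C/C(=N\NC(=O)COc1cccc2ccccc12)c1cccc([N+](=O)[O-])c1` is the next compound to be measured in this assay. It differs from compound 3 in one place: 3-nitrophenyl in place of 2-hydroxyphenyl on a carbon with a double bond to nitrogen. Within the data shown here, the steps that bear on this change are the two that swap one aryl group for another on the same carbon, a 5.0-fold higher number from compound 1 to compound 2 (0.70 log units; beyond the scatter) and a 5.0-fold lower number from compound 2 to compound 3 (0.70 log units; beyond the scatter), both of modest size and both pointing to the 4-nitrophenyl compound as the one with the higher number. A 3-nitrophenyl is not the same group, so only part of that shift is expected here. For compound 4 the estimate is 50 ug/mL, in the range 20 ug/mL to 100 ug/mL, which would mean an expected 2.5-fold higher number from compound 3 to compound 4 (0.40 log units; beyond the scatter).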

Compound 4, minimum cytotoxic concentration: 20 ug/mL
For compound 4 the middle estimate is 2.5-fold (0.40 log units) above the measured one; the measured number falls inside the stated range.
By their numbers in this assay, from the lowest: compounds 1, 3 and 4 (each within the scatter of the next); then compound 2.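

In this assay, 3-nitrophenyl in place of 4-nitrophenyl gives a 5.0-fold lower number from compound 2 to compound 4 (0.70 log units; beyond the scatter), so carrying a nitro group is not enough for the higher number here, and among these two compounds the difference goes with where the nitro group sits on the phenyl ring. Compound 4 instead joins the lower group of the set, with no change at the digits printed from compound 3 to compound 4 (within the scatter) and no change at the digits printed from compound 1 to compound 4 (within the scatter), which leaves compound 2 as the only one of the four aryl groups on this carbon with a double bond to nitrogen to stand apart. Nothing at hand explains why the two nitrophenyl compounds differ.

Still open, as far as these compounds go, is whether the higher number of compound 2 belongs to the nitro group alone or would also come with a 4-aminophenyl or a 4-carboxyphenyl on the same carbon.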